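This account rests on a few compounds, and the source may have more. Where it says the series, first, only, none or still open, it means among the compounds named here.

Measured compounds:
- compound 1 `O=C(CN1C(=O)/C(=C/c2ccc(-c3ccc(Cl)cc3)o2)SC1=S)NCc1ccc(F)cc1`: 165000 nM
- compound 2 `COc1ccc(CNC(=O)CN2C(=O)/C(=C/c3ccc(-c4ccc(Cl)cc4)o3)SC2=S)cc1`: 44000 nM

Both compounds share the same core and differ only on the six-membered aromatic ring of carbon only that carries the benzyl amide. In a functional assay on REH cells (Homo sapiens) for cytotoxicity, read by MTT assay, with a stated time of 72 h (on this read-out lower numbers stand for stronger inhibition and higher numbers for weaker inhibition), compound 1 gives 165000 nM, while compound 2 gives 44000 nM. Among the measured compounds shown here, the single measured step, a 3.8-fold lower number from compound 1 to compound 2 (0.57 log units; beyond the scatter), is beyond the scatter, so compound 2 stands as the lower of the two numbers in this assay.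

Compound 3 `Cc1ccc(CNC(=O)CN2C(=O)/C(=C/c3ccc(-c4ccc(Cl)cc4)o3)SC2=S)cc1` is not yet measured. It differs from compound 2 by methyl in place of methoxy on an aromatic carbon; the group sits on an aromatic carbon of a six-membered aromatic ring of carbon only, para to a large group. For the measured compounds named here, no measured step covers a methoxy-to-methyl exchange, so the one step from compound 1 to compound 2 bears only loosely on it: it shows that this position tolerates a change of group with a modest shift, but it gives no direction for the present change. Compound 3 is therefore expected to land close to compound 2, with an estimated step of a 1.3-fold higher number from compound 2 to compound 3 (0.10 log units; within the scatter). Compound 3 is expected to give about 55000 nM in this assay, within a range of 20000 nM to 150000 nM.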

Compound 3, half-maximal inhibitory concentration: 45000 nM
Beside the measured number, compound 3's estimate is 1.2-fold (0.09 log units) above it; the range from low to high includes it.
By their numbers in this assay, from the lowest: compounds 2 and 3 (each within the scatter of the next); then compound 1.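

In this assay the change from methoxy to methyl, on an aromatic carbon para to a large group, gives a 1.0-fold higher number from compound 2 to compound 3 (0.01 log units; within the scatter) and so shows that the 4-methoxybenzyl group can give way to the 4-methylbenzyl group with no reading difference, although one heavy atom and the hydrogen-bond acceptor counted on methoxy are lost. Compound 1 now stands apart from two neighbours rather than one, with a 3.7-fold lower number from compound 1 to compound 3 (0.56 log units; beyond the scatter) alongside a 3.8-fold lower number from compound 1 to compound 2 (0.57 log units; beyond the scatter) as steps beyond the scatter, so in these three compounds fluoro carries the higher number while methoxy and methyl do not separate. The data on hand offer nothing that explains why methoxy and methyl read alike or why fluoro reads higher.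

The compounds shown leave open how an amine, a carboxylic acid or a longer alkyl chain would read at this position, and whether a benzyl ring with no group there would fall with compound 1 or with compound 3. They also leave open whether the same order would hold in any other cell line.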